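Amide-substituent changes on a shared core

The source may hold more compounds than are shown below. What is called first, only, known or untested is meant among the compounds shown, and "the series" means these compounds.

compound 1 `O=C(NC1CCN(C2CC2)C1)c1cc(-c2ccc(NS(=O)(=O)c3cccc(Cl)c3Cl)cc2)nc2[nH]ncc12`: in an assay for inhibition of serine/threonine-protein kinase Sgk1 (Homo sapiens), with stated times of 30 min and 60 min, in the presence of a further agent that is not named here (a lower number here means a stronger inhibitor, a higher number a weaker inhibitor), compound 1 gives 6 nM
compound 2 `CCNC(=O)c1cc(-c2ccc(NS(=O)(=O)c3cccc(Cl)c3Cl)cc2)nc2[nH]ncc12`: in this assay compound 2 gives 6 nM

In this assay compound 2 stands level with compound 1 at the digits shown; the nearest measured neighbour is compound 1. Among the compounds with values here, the only measured step, no change at the digits printed from compound 1 to compound 2 (within the scatter), exchanges the group on the amide-type nitrogen and lies within the scatter. Compound 3 `CCN1CCC(CNC(=O)c2cc(-c3ccc(NS(=O)(=O)c4cccc(Cl)c4Cl)cc3)nc3[nH]ncc23)C1` carries 1-ethylpyrrolidin-3-yl in place of methyl on a saturated chain carbon bound to an amide-type nitrogen. Within the data shown here, this again alters only the substituent on the amide-type nitrogen, so on the single bearing step no change beyond the scatter is expected in this assay. Compound 3 is therefore estimated at 6 nM, range 3 nM to 15 nM. The expected step is no change at the digits printed from compound 2 to compound 3 (within the scatter).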

Compound 3, half-maximal inhibitory concentration: < 1 nM
Compound 3: only a limit was reported (the forecaster's own chance of this, stated with the estimate: 2%); middle value at least 6.0-fold (0.77 log units) from the limit.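

Substitution on the amide-type nitrogen can move this assay after all: the change to (1-ethylpyrrolidin-3-yl)methyl gives an at least 6.0-fold lower number from compound 2 to compound 3 (0.77 log units; beyond the scatter), and against 1-cyclopropylpyrrolidin-3-yl it gives an at least 6.0-fold lower number from compound 1 to compound 3 (0.77 log units; beyond the scatter). Compound 1 also carries a pyrrolidine ring yet stands level with compound 2, so that ring alone does not set compound 3 apart. Compound 3 is reported only as a limit: the limit of < 1 nM in this assay, at which 1 of the 3 values shown sits.

The compounds shown do not separate the part played by the added chain carbon from that of the ethyl group on the ring. A (1-cyclopropylpyrrolidin-3-yl)methyl group on the amide nitrogen would bear on this directly.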